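This account rests on a few compounds, and the source may have more. Where it says the series, first, only, none or still open, it means among the compounds named here.

Measured in a functional assay on SK-MEL-28 cells (Homo sapiens) for cytotoxicity, read by CCK-8 assay, with a stated time of 24 h; a higher number here means a weaker inhibitor, a lower number a stronger inhibitor:
- compound 1 `COc1ccccc1Oc1c(N)nc(-c2ccc(F)cc2)nc1OCCO`: 20100 nM
- compound 2 `COc1ccccc1Oc1c(N)nc(-c2ccc(Cl)cc2)nc1OCCO`: > 80000 nM (a limit)

Compound 2 has no number, only a limit: the limit of > 80000 nM in this assay, at which 1 of the 2 values shown sits. Compound 3 `COc1ccccc1Oc1c(N)nc(-c2ccc(Br)cc2)nc1OCCO` differs from compound 2 by bromo in place of chloro on an aromatic carbon. Among the measured compounds shown here, one measured step bears on this: an at least 3.9-fold higher number from compound 1 to compound 2 (0.59 log units; beyond the scatter), with chloro in place of fluoro. That step is open-ended, so in this assay a weak compound is expected again, with no clear step beyond the scatter. The estimated step is a number no higher from compound 2 to compound 3 (the limit leaves the size open). For compound 3 the expected value is 80000 nM, with an estimated range of 30000 nM to 160000 nM.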

Compound 3, half-maximal inhibitory concentration: 4400 nM
For compound 3 the middle estimate is 18-fold (1.26 log units) above the measured one; measured number below the stated range.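

In this assay, bromo in place of chloro gives an at least 18-fold lower number from compound 2 to compound 3 (1.25 log units; beyond the scatter), and bromo in place of fluoro gives a 4.6-fold lower number from compound 1 to compound 3 (0.66 log units; beyond the scatter). The number therefore does not run in one direction through the halogens at this place: compound 2 goes against any steady trend from fluoro to bromo, and compound 3 is the strongest of the three. Compound 2 has a limit and not a number, so the first step stays open-ended: the limit of > 80000 nM in this assay, at which 1 of the 3 values shown sits.

As far as these compounds go, whether this gain is particular to bromo remains open. Iodo, methyl, an amine or a carboxylic acid at this place could test that.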